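This account rests on a few compounds, and the source may have more. Where it says the series, first, only, none or still open, it means among the compounds named here.

In an assay for inhibition of Nicotinamide phosphoribosyltransferase (Homo sapiens), read by mass spectrometry, with stated times of 15 min and 30 min (a higher number here means a weaker inhibitor, a lower number a stronger inhibitor), three compounds have been examined. Compound 1 `Cn1c(C(=O)NCc2ccc(S(=O)(=O)c3ccccc3)cc2)cc2cnccc21` gives > 10000 nM, which is a limit of the assay rather than a number. Compound 2 `O=C(NCc1ccc(S(=O)(=O)N2CCCCC2)cc1)c1cc2cnccc2s1` gives 150 nM, and compound 3 `O=C(NCc1ccc(S(=O)(=O)c2ccccc2)cc1)c1cc(-c2cccnc2)no1` gives 41 nM. Going by the values given here, of the two numbers known, compound 2 has the higher, so it is the weaker inhibitor of that pair; the gap between compound 2 and compound 3 lies beyond the usual scatter of this assay.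

Compound 4 `O=C(NCc1ccc(S(=O)(=O)N2CCCCC2)cc1)c1cc2ccncc2o1` has not yet been measured in this assay. It differs from compound 2 in one place, on a carbonyl carbon whose other neighbours are an amide-type nitrogen: a group of 9 heavy atoms (7 carbon, 1 nitrogen, 1 oxygen; one five-membered aromatic ring with 1 hetero atom, one six-membered aromatic ring with 1 hetero atom) in place of a group of 9 heavy atoms (7 carbon, 1 nitrogen, 1 sulfur; one five-membered aromatic ring with 1 hetero atom, one six-membered aromatic ring with 1 hetero atom), on a carbonyl carbon. The sulfonyl group attached to a six-membered saturated nitrogen ring, the benzylic amide and the rest of the molecule are kept as in compound 2.

Among the compounds with values here, no pair of measured compounds here differs in exactly one place, so no measured step can be taken as a guide for this change. The exchange of one hetero atom in the fused bicyclic amide is expected to move the number in this assay little, perhaps slightly upward, and most likely within or just past the scatter. Compound 4 is therefore expected to give about 250 nM, within a range from 80 nM to 800 nM. This means an expected step of a 1.7-fold higher number from compound 2 to compound 4 (0.22 log units; within the scatter).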

Compound 4, half-maximal inhibitory concentration: 40 nM
Estimate against measurement, compound 4: 6.3-fold (0.80 log units) above; measured number outside the range, below it.
By their numbers in this assay, from the lowest: compounds 4 and 3 (each within the scatter of the next); then compound 2. At a limit, above all of these: compound 1.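

In this assay, putting the oxygen-containing fused group in place of the sulfur-containing one on the carbonyl carbon gives a 3.8-fold lower number from compound 2 to compound 4 (0.57 log units; beyond the scatter). This is the first measured step among these compounds, and it shows that the number responds to a change at this place even though the two groups match in heavy-atom count, ring types, and counts of hydrogen-bond donors and acceptors, while the sulfonyl group on the six-membered saturated nitrogen ring and the benzylic amide stay as they were. Nothing measured here accounts for the size of this step.

The step belongs to the whole exchanged group, so the compounds shown do not separate the oxygen for sulfur from any other difference between the two fused groups, and a single step cannot show whether the same exchange would act alike with the phenyl sulfonyl group of compound 3. Going by these compounds, how an amine or a carboxylic acid on the fused rings would read in this assay also remains open.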